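The compounds below may be only part of what the source reports. "The series", "measured", "known", "first", "only" and "open" are said of these compounds alone.

Three compounds have been measured in a functional assay on MCF7 cells (Homo sapiens) for antiproliferative activity, read by MTT assay, with a stated time of 72 h; a higher number here means a weaker inhibitor, a lower number a stronger inhibitor:

Compound 1 `Cc1ccc(S(=O)(=O)NCc2cn(C[C@H](O)[C@H]3OC(=O)C(OCc4ccccc4)=C3OCc3ccccc3)nn2)cc1` gives 6400 nM.
Compound 2 `O=C1O[C@H]([C@@H](O)Cn2cc(CNS(=O)(=O)c3ccc(F)cc3)nn2)C(OCc2ccccc2)=C1OCc1ccccc1` gives 26800 nM.
Compound 3 `CCCCCc1ccc(-c2cn(C[C@H](O)[C@H]3OC(=O)C(OCc4ccccc4)=C3OCc3ccccc3)nn2)cc1` gives 9010 nM.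

Compound 3 stands second highest of the three. Its nearest neighbour is compound 1, since a 1.4-fold higher number from compound 1 to compound 3 (0.15 log units; within the scatter) lies within the scatter; its furthest is compound 2, with a 3.0-fold lower number from compound 2 to compound 3 (0.47 log units; beyond the scatter) beyond it. Compound 4 `O=C1O[C@H]([C@@H](O)Cn2cc(-c3ccc(Br)cc3)nn2)C(OCc2ccccc2)=C1OCc1ccccc1` differs from compound 3 by bromo in place of pentyl on an aromatic carbon. Within the data shown here, no measured step swaps a pentyl for a bromo. Among the measured compounds shown here, the only step that trades one small group for another on an aromatic carbon is a 4.2-fold higher number from compound 1 to compound 2 (0.62 log units; beyond the scatter), a modest weakening, but it sits on a different part of the molecule. For compound 4 a small upward step, a 1.3-fold higher number from compound 3 to compound 4 (0.12 log units; within the scatter), is therefore expected. Compound 4 is estimated at 12000 nM, within 5000 nM to 30000 nM.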

Compound 4, half-maximal inhibitory concentration: 5620 nM
Beside the measured number, compound 4's estimate is 2.1-fold (0.33 log units) above it; measured number inside the range.
By their numbers in this assay, from the lowest: compounds 4, 1 and 3 (each within the scatter of the next); then compound 2.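

Pentyl and bromo give numbers that cannot be told apart at this aromatic carbon in this assay (a 1.6-fold lower number from compound 3 to compound 4 (0.20 log units; within the scatter)), so the long chain shows no advantage over the single halogen here. The 4-bromophenyl group also matches the (((4-methylphenyl)sulfonyl)amino)methyl group (a 1.1-fold lower number from compound 1 to compound 4 (0.06 log units; within the scatter)), while the (((4-fluorophenyl)sulfonyl)amino)methyl group stands clearly apart (a 4.8-fold lower number from compound 2 to compound 4 (0.68 log units; beyond the scatter)). No measurement at hand explains these results.

Going by these compounds, it remains open whether an amine or a carboxylic acid at this carbon would shift the number. The effect of a shorter chain, such as ethyl, is also unknown.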